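Trifluoromethyl Added to Compound 3: What to Expect

The compounds below may be only part of what the source reports. "The series", "measured", "known", "first", "only" and "open" are said of these compounds alone.

Of the compounds shown here, three on a shared core have been measured in an ADME assay on Vero 76 cells (Chlorocebus sabaeus) for cytotoxicity, read by MTT assay, with a stated time of 96 h; a higher number here means that more compound is tolerated, a lower number that less compound is tolerated. Compound 3 `Clc1ccc(NCc2cn(-c3ccccc3)nc2-c2ccccc2)cc1` gives 65000 nM, the highest of the two single numbers available. Its nearest neighbour is compound 2 `FC(F)(F)c1ccc(NCc2cn(-c3ccccc3)nc2-c2ccc(C(F)(F)F)cc2)cc1`, which in this assay gives 26000 nM, a lower number that lies beyond the usual scatter. Compound 1 `Clc1ccc(NCc2cn(-c3ccccc3)nc2-c2ccc(Br)cc2)cc1` has several entries in this assay, 43000 nM; > 100000 nM (2 entries).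

Compound 4 `FC(F)(F)c1ccc(-c2nn(-c3ccccc3)cc2CNc2ccc(Cl)cc2)cc1` has not yet been measured in this assay. It differs from compound 3 by trifluoromethyl in place of hydrogen on an aromatic carbon. Going by the values given here, since no step between measured compounds differs in one place only, no direct precedent exists; compound 2, carrying trifluoromethyl groups, stands lower than compound 3, so a modest fall is the expectation. The step from compound 3 to compound 4 is expected to be a 1.6-fold lower number from compound 3 to compound 4 (0.21 log units; within the scatter), toward a lower number but possibly within the scatter. Compound 4 is therefore estimated at 40000 nM, between 20000 nM and 80000 nM.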

Compound 4, half-maximal cytotoxic concentration: 10000 nM
Compound 4: the middle estimate sits 4.0-fold (0.60 log units) above what was measured, and the stated range ends above it.
By their numbers in this assay, from the lowest: compound 4; then compound 2; then compound 3.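

In this assay this position now has its first single-place step: trifluoromethyl in place of hydrogen, para to a large group, gives a 6.5-fold lower number from compound 3 to compound 4 (0.81 log units; beyond the scatter) and so moves the number beyond the scatter. A second place reads differently, since chloro in place of trifluoromethyl on an aromatic carbon gives a 2.6-fold lower number from compound 2 to compound 4 (0.41 log units; beyond the scatter) and thus trifluoromethyl does not go with a lower number at every place on the shared core. Bromo at the first place offers only a loose comparison, as the entries for that compound do not agree on one number and include a limit of the assay: the several entries of compound 1 in this assay, 43000 nM; > 100000 nM (2 entries).

The compounds shown leave open whether the fall belongs to trifluoromethyl alone or would also follow a methoxy group or a nitrile at this position. They also do not show where an amine or a carboxylic acid there would stand in this assay on this scale.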